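Changing One Carbonyl Substituent of Compound 3

A few compounds are considered here, and "the series" means these few. Any claim that something is new, unique, unknown or untested is made for them only; others in the source may bear on it.

In a functional assay on MIA PaCa-2 cells (Homo sapiens) for antiproliferative activity, read by sulforhodamine B assay, with a stated time of 48 h (on this read-out lower numbers stand for stronger inhibition and higher numbers for weaker inhibition), compound 3 (`COc1cc(OC)c2sc(-c3ccc(N/C=C\C(=O)c4cc(OC)c(OC)c(OC)c4)c(C)c3)nc2c1`) gives 17000 nM. This number is within the scatter of compound 1 (`COc1cc(OC)c2sc(-c3ccc(N/C=C\C(=O)c4ccc(OC)c([N+](=O)[O-])c4)c(C)c3)nc2c1`), which gives 13900 nM, whereas compound 2 (`COc1ccc(C(=O)/C=C\Nc2ccc(-c3nc4cc(OC)c(OC)c(OC)c4s3)cc2C)cc1F`) gives a distinctly lower 1800 nM.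

Compound 4 (`COc1cc(OC)c2sc(-c3ccc(N/C=C\C(=O)c4ccc(OC)c(F)c4)c(C)c3)nc2c1`) keeps the core of compound 3 and differs at a single place, on a carbonyl carbon: 3-fluoro-4-methoxyphenyl in place of 3,4,5-trimethoxyphenyl on a carbonyl carbon.

Two measurements bear on this change. Going by the values given here, the one measured swap at this place, a 1.2-fold higher number from compound 1 to compound 3 (0.09 log units; within the scatter), stays within the scatter, so it gives no sign of a large effect there. Compound 4, however, carries the same 3-fluoro-4-methoxyphenyl group as compound 2, which has a different core, and compound 2 reaches 1800 nM. Its core differs, so only part of that gap can be expected to carry over.

The expected change is a moderate move towards a lower number, a 2.8-fold lower number from compound 3 to compound 4 (0.45 log units; beyond the scatter). For compound 4 the estimated value is 6000 nM, with an expected range from 1900 nM to 18000 nM.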

Compound 4, half-maximal inhibitory concentration: 16300 nM
Compound 4: middle estimate off by 2.7-fold (0.43 log units), on the low side; measured number inside the range.
By their numbers in this assay, from the lowest: compound 2; then compounds 1, 4 and 3 (each within the scatter of the next).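

In this assay, changing the group on the carbonyl carbon makes no difference that can be read on this core: the change gives a 1.0-fold lower number from compound 3 to compound 4 (0.02 log units; within the scatter), and swapping fluoro for nitro on that aromatic ring gives a 1.2-fold higher number from compound 1 to compound 4 (0.07 log units; within the scatter). The large gap lies at a different place, with hydrogen in place of methoxy on an aromatic carbon of the core, which gives a 9.1-fold higher number from compound 2 to compound 4 (0.96 log units; beyond the scatter), so the low number of compound 2 goes with that extra methoxy and not with the 3-fluoro-4-methoxyphenyl group alone. Nothing measured here explains why either change has the effect it does.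

On these data alone, whether the group on the carbonyl carbon matters on the core of compound 2 remains open. So does the effect of an amine or a carboxylic acid on that aromatic ring.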